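This account rests on a few compounds, and the source may have more. Where it says the series, first, only, none or still open, it means among the compounds named here.

Measured so far:
- Compound 1 `COC(=O)CNC(=O)NCc1ccc(C(=O)N2CCCCc3ccccc32)cc1C`: 37 nM
- Compound 2 `Cc1cc(C(=O)N2CCCCc3ccccc32)ccc1CNC(=O)NCC(N)=O`: 210 nM
- Compound 3 `Cc1cc(C(=O)N2CCCCc3ccccc32)ccc1CNC(=O)NCC(=O)N1CCCCC1`: 150 nM

All three share the same core and differ only in the group hanging from the urea end of the molecule. In a functional assay on HEK293 cells for agonist activity at Vasopressin V2 receptor (Homo sapiens), read by a luciferase reporter and cAMP accumulation (a lower number here means that less compound is needed, a higher number that more compound is needed for the effect), compound 3 stands second highest of the three numbers: its nearest neighbour is compound 2, which gives a number higher by a 1.4-fold lower number from compound 2 to compound 3 (0.15 log units; within the scatter), a gap within the scatter, while compound 1 sits furthest away, with a 4.1-fold higher number from compound 1 to compound 3 (0.61 log units; beyond the scatter) placing compound 3 clearly above it.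

Compound 4 `Cc1cc(C(=O)N2CCCCc3ccccc32)ccc1CNC(=O)N1CCC[C@H]1C(=O)O` has not been measured. It differs from compound 3 in one place: 2-carboxypyrrolidin-1-yl in place of (((piperidin-1-yl)carbonyl)methyl)amino on a carbonyl carbon. The whole flexible side chain is thus replaced by a ring that carries a free carboxylic acid, with one defined stereocentre.

The measured steps that change this same end of the molecule are a 5.7-fold higher number from compound 1 to compound 2 (0.75 log units; beyond the scatter) and a 4.1-fold higher number from compound 1 to compound 3 (0.61 log units; beyond the scatter), both modest and beyond the scatter, while a 1.4-fold lower number from compound 2 to compound 3 (0.15 log units; within the scatter) shows that exchanging one amide terminus for another makes no difference beyond the scatter. For the measured compounds named here, none of the measured compounds carries an acid or a ring directly on the urea nitrogen, so the expectation rests on the general finding that changes here move the number by modest amounts. Compound 4 is therefore expected to give a step of a 2.0-fold higher number from compound 3 to compound 4 (0.30 log units; within the scatter) in this assay, with wide uncertainty. The estimated value for compound 4 is 300 nM, within a range from 60 nM to 1500 nM.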

Compound 4, half-maximal effective concentration: 680 nM
For compound 4 the middle estimate is 2.3-fold (0.36 log units) below the measured one; low and high end bracket the measured number.
By their numbers in this assay, from the lowest: compound 1; then compounds 3 and 2 (each within the scatter of the next); then compound 4.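

In this assay the swap to 2-carboxypyrrolidin-1-yl raises the number beyond the scatter, both against the piperidine amide end (a 4.5-fold higher number from compound 3 to compound 4 (0.66 log units; beyond the scatter)) and against the primary amide end (a 3.2-fold higher number from compound 2 to compound 4 (0.51 log units; beyond the scatter)), whereas exchanging one of those amide ends for the other stayed within the scatter (a 1.4-fold lower number from compound 2 to compound 3 (0.15 log units; within the scatter)). Against the methyl ester end of compound 1 the step is the first large one seen at this position (an 18-fold higher number from compound 1 to compound 4 (1.26 log units; beyond the scatter)), so this end of the molecule can shift the number by more than the modest steps among the earlier compounds, and compound 4 now has the highest number of the four. No measured property is available to account for this rise.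

The change brings in a ring, a carboxylic acid and a defined stereocentre all at once, so these compounds leave open which of them matters most. A plain pyrrolidin-1-yl without the carboxylic acid, an open-chain (carboxymethyl)amino group, or the methyl ester of the same ring, each placed on the same carbonyl carbon, would help pull these features apart, and the opposite stereoisomer also remains an open question.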